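Amide side-chain swap, compound 3 to compound 4

The source may report more compounds than this note shows. Statements on the series, on what has been measured and on what is new or still open speak of the compounds shown alone.

In an ADME assay on MRC5 cells (Homo sapiens) for antiproliferative activity, read by fluorescence and resazurin assay, with a stated time of 68 h (on this read-out higher numbers stand for an effect only at larger amounts of compound and lower numbers for an effect already at smaller amounts), three amides on the shared core have been measured. Compound 1 (`Cc1ccc(-c2cc(C(=O)NCCN(C)C)c3cc(Cl)ccc3n2)cc1`) gives 9000 nM, compound 2 (`Cc1ccc(-c2cc(C(=O)NCCCN(C)C)c3cc(Cl)ccc3n2)cc1`) gives 6000 nM and compound 3 (`Cc1ccc(-c2cc(C(=O)NCCN3CCN(C)CC3)c3cc(Cl)ccc3n2)cc1`) gives 8000 nM. These numbers lie within the scatter of one another, so compound 3 holds no distinct place among them.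

Compound 4 (`Cc1ccc(-c2cc(C(=O)NCCN3CCCC3)c3cc(Cl)ccc3n2)cc1`) carries pyrrolidin-1-yl in place of 4-methylpiperazin-1-yl on a saturated chain carbon, two bonds along the chain from an amide-type nitrogen.

Three measured changes at this same place bear on it: a 1.1-fold lower number from compound 1 to compound 3 (0.05 log units; within the scatter), a 1.5-fold lower number from compound 1 to compound 2 (0.18 log units; within the scatter) and a 1.3-fold higher number from compound 2 to compound 3 (0.12 log units; within the scatter). Each lies within the scatter. For the measured compounds named here, no measured compound carries pyrrolidin-1-yl, so this support is indirect, and no step beyond the scatter is expected in either direction.

The expected step is a 1.1-fold lower number from compound 3 to compound 4 (0.03 log units; within the scatter).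

For compound 4, the estimated value is 7500 nM, with an expected range of 4000 nM to 14000 nM.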

Compound 4, half-maximal effective concentration: 7000 nM
Estimate against measurement, compound 4: 1.1-fold (0.03 log units) above; the range from low to high includes it.
By their numbers in this assay, from the lowest: compounds 2, 4, 3 and 1 (each within the scatter of the next).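

In this assay pyrrolidin-1-yl, on a saturated chain carbon, two bonds along the chain from an amide-type nitrogen, does not separate from any of the earlier groups at this place (a 1.1-fold lower number from compound 3 to compound 4 (0.06 log units; within the scatter)) (a 1.2-fold higher number from compound 2 to compound 4 (0.07 log units; within the scatter)) (a 1.3-fold lower number from compound 1 to compound 4 (0.11 log units; within the scatter)). The five-membered non-aromatic ring with 1 hetero atom therefore cannot be told apart here from the six-membered non-aromatic ring with 2 hetero atoms of 4-methylpiperazin-1-yl, and all four side chains now sit within the scatter of one another. No data that could account for these numbers accompany the result.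

Open, as far as these compounds go, is whether a group at this place with no amine, such as a hydroxyl or a carboxylic acid, would step beyond the scatter. From the compounds shown here alone, a longer chain than 2-(pyrrolidin-1-yl)ethyl also remains open.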